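This account rests on a few compounds, and the source may have more. Where it says the series, first, only, none or still open, it means among the compounds named here.

Compound 1 `COc1ccc(-c2cnc(NC(=O)c3ccc(O)cc3)n2C)cc1`: > 100000 nM
Compound 2 `COc1ccc(-c2cnc(NC(=O)c3ccccc3C)n2C)cc1`: > 100000 nM
Compound 3 `COc1ccc(-c2cnc(NC(=O)c3cccc(Cl)c3)n2C)cc1`: > 28000 nM

All three values in a toxicity assay on THP-1 cells (Homo sapiens) for inhibition (a lower number here means that less compound is tolerated, a higher number that more compound is tolerated), are limits and not numbers. Compound 3 therefore has only a limit, > 28000 nM. Compound 4 `COc1ccc(-c2cnc(NC(=O)c3ccccc3Br)n2C)cc1` differs from it on the carbonyl carbon: 2-bromophenyl in place of 3-chlorophenyl on a carbonyl carbon. The measured steps that bear on this change are a step that the two limits leave unreadable from compound 2 to compound 3 and a step that the two limits leave unreadable from compound 1 to compound 3, and neither has a readable size. Compound 2, which carries 2-methylphenyl, also has only a limit, > 100000 nM. No step beyond the scatter is expected in this assay, and no direction can be assigned, so the estimated step is a step that the limit leaves unreadable from compound 3 to compound 4. Compound 4 is expected at 50000 nM, within an estimated range of 20000 nM to 120000 nM.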

Compound 4, half-maximal cytotoxic concentration: > 100000 nM
Compound 4 ended at the assay's limit; the forecaster's own chance of this, stated with the estimate: 80%; middle value at least 2.0-fold (0.30 log units) away from the limit.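

Compound 4 also gives only a limit, so its steps from compound 1, compound 2 and compound 3 cannot be read in this assay: the limit of > 100000 nM in this assay, at which 3 of the 4 values shown sit.

The compounds shown leave open whether any group on the carbonyl carbon changes how much compound is tolerated.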